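This account rests on a few compounds, and the source may have more. Where it says the series, first, only, none or still open, it means among the compounds named here.

Working notes on the series.

Going by the values given here, compound 2, `CC(C)c1cccc(OC(=O)c2cn(-c3ccccc3)nc2-c2cccnc2)c1`, is one of two compounds measured in a functional assay on HL-60 cells (Homo sapiens) for cytotoxicity, read by MTT assay, with a stated time of 48 h; a lower number here means a stronger inhibitor, a higher number a weaker inhibitor. Compound 1, `O=C(c1cn(-c2ccccc2)nc1-c1cccnc1)N1CCC(Cc2ccccc2)CC1`, in this assay gives 16100 nM; compound 2 in this assay gives 23700 nM. Among the compounds with values here, the gap between these two numbers lies within the usual scatter of repeated measurements, so compound 2 cannot be told apart from compound 1 on what is known, and no step between them is recorded.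

Compound 3, `Cc1ccc(C(C)C)c(OC(=O)c2cn(-c3ccccc3)nc2-c2cccnc2)c1`, differs from compound 2 in one place: 2-isopropyl-5-methylphenyl in place of 3-isopropylphenyl on an oxygen next to a carbonyl group. Within the data shown here, no measured pair reports what such a change does, so nothing beyond the scatter is expected in either direction.

Compound 3 is therefore estimated to show a step of about a 1.1-fold lower number from compound 2 to compound 3 (0.03 log units; within the scatter) from compound 2 in this assay, which amounts to no change beyond the scatter. Compound 3 is expected to give 22000 nM, with a range from 8000 nM to 60000 nM.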

Compound 3, half-maximal inhibitory concentration: 22700 nM
Beside the measured number, compound 3's estimate is 1.0-fold (0.01 log units) below it; the range from low to high includes it.
By their numbers in this assay, from the lowest: compounds 1, 3 and 2 (each within the scatter of the next).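

In this assay, putting 2-isopropyl-5-methylphenyl in place of 3-isopropylphenyl on an oxygen next to a carbonyl group gives a 1.0-fold lower number from compound 2 to compound 3 (0.02 log units; within the scatter). Going by these compounds alone, this is the first single-place comparison, as the earlier compounds offered no such pair. At this place, the group of 9 heavy atoms and the group of 10 heavy atoms cannot be told apart, so this change gives no handle on the number. No measurement at hand gives a reason for this result.

The compounds shown leave open whether a plain phenyl, with no isopropyl group, would give a number apart from those of compound 2 and compound 3. From the compounds shown here alone, it also remains open whether an aminophenyl or a carboxyphenyl group on this oxygen would produce a step beyond the scatter.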